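Shortening the alkyne chain on a shared uracil core

The compounds below may be only part of what the source reports. "The series", "measured", "known", "first", "only" and "open" are said of these compounds alone.

Of the compounds shown here, three have been measured in a functional assay on MOLT-4 cells (Homo sapiens) for antiproliferative activity, read by MTT assay, with a stated time of 3 days; on this read-out higher numbers stand for weaker inhibition and lower numbers for stronger inhibition. Compound 2 `CCCCCCC#Cc1cn(C/C=C/CN2C(=O)c3ccccc3C2=O)c(=O)[nH]c1=O` gives 35000 nM. Compound 3 `CCCCc1ccc(C#Cc2cn(C/C=C/CN3C(=O)c4ccccc4C3=O)c(=O)[nH]c2=O)cc1` gives 29000 nM, and compound 1 `O=C1c2ccccc2C(=O)N1C/C=C\Cn1cc(C#Cc2ccc(Br)cc2)c(=O)[nH]c1=O` gives 89000 nM. Among these three numbers compound 2 stands second highest: compound 3 is its nearest neighbour and lies within the scatter of it, while compound 1 is furthest away and lies beyond the scatter. Compound 1 differs from compound 2 in more than one place, so only its value can be compared, not a single step. Within the data shown here, the one step that can be computed, a 1.2-fold lower number from compound 2 to compound 3 (0.08 log units; within the scatter), replaces the whole hexyl chain on the triple-bonded carbon with 4-butylphenyl and does not move the number beyond the scatter.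

Compound 4 `CCCCC#Cc1cn(C/C=C/CN2C(=O)c3ccccc3C2=O)c(=O)[nH]c1=O` has not yet been measured. It differs from compound 2 by hydrogen in place of ethyl on a saturated chain carbon, four bonds along the chain from a triple-bonded carbon. Among the measured compounds shown here, no measured pair shows this same change. Since the far larger exchange seen in a 1.2-fold lower number from compound 2 to compound 3 (0.08 log units; within the scatter) stayed within the scatter, a change confined to the outer part of the chain is not expected to move this assay far either. Compound 4 is therefore expected to give about 45000 nM, with a range from 20000 nM to 100000 nM. The expected step of a 1.3-fold higher number from compound 2 to compound 4 (0.11 log units; within the scatter) is estimated to lie within the scatter, if anything toward a slightly higher number.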

Compound 4, half-maximal inhibitory concentration: 171000 nM
Compound 4: middle estimate off by 3.8-fold (0.58 log units), on the low side; measured number outside the range, above it.
By their numbers in this assay, from the lowest: compounds 3 and 2 (each within the scatter of the next); then compounds 1 and 4 (each within the scatter of the next).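

In this assay the outer end of the chain turns out to count, for hydrogen in place of ethyl on a saturated chain carbon, four bonds along the chain from a triple-bonded carbon, gives a 4.9-fold higher number from compound 2 to compound 4 (0.69 log units; beyond the scatter) and so moves the number beyond the scatter. The earlier pair had made this position look flat, with hexyl and 4-butylphenyl on the triple-bonded carbon lying within the scatter of each other, but butyl on that carbon does not join them, as a 5.9-fold higher number from compound 3 to compound 4 (0.77 log units; beyond the scatter) is also beyond the scatter. Among compounds 2, 3 and 4, which differ only in the group on the triple-bonded carbon, the butyl compound 4 alone stands apart, with the higher number.

No supporting data bear on why the number rises with this change. From the compounds shown here alone, what a pentyl chain or a longer chain such as octyl would give on the triple-bonded carbon remains open, and so does whether the number changes gradually along the chain or at one point.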